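The source may hold more compounds than are shown below. What is called first, only, known or untested is meant among the compounds shown, and "the series" means these compounds.

For the measured compounds named here, in an ADME assay on microsomes from liver (Homo sapiens) for metabolic stability, read by LC-MS, using NADPH, with a stated time of 30 min, tested at 0.1 uM (on this read-out lower numbers stand for a less stable compound and higher numbers for a more stable compound), compound 1 (`O=S(=O)(CCO)c1cccc(-c2ccc3nccc(-c4ccncc4)c3n2)c1`) gives 95% and compound 2 (`CS(=O)(=O)Nc1cccc(-c2ccc3nccc(-c4ccncc4)c3n2)c1`) gives 59% as the lower of the two numbers so far. Going by the values given here, the only measured step is a number 36 percentage points lower from compound 1 to compound 2 (beyond the scatter) and it puts methanesulfonamido in place of (2-hydroxyethyl)sulfonyl on an aromatic carbon. Compound 3 (`O=S(=O)(c1cccc(-c2ccc3nccc(-c4ccncc4)c3n2)c1)N1CC[C@H](O)C1`) has not been measured. It differs from compound 2 by (3-hydroxypyrrolidin-1-yl)sulfonyl in place of methanesulfonamido on an aromatic carbon in one place, with (3-hydroxypyrrolidin-1-yl)sulfonyl in place of methanesulfonamido on an aromatic carbon.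

The large measured step bears on this change, which removes the same methanesulfonamido and again places a sulfonyl group on the aromatic carbon, as in compound 1 at 95%. Among the compounds with values here, no measured step covers the five-membered ring or the defined stereocentre, so only part of that large step is expected to return. A higher number of moderate to large size, beyond the scatter, is expected in this assay. The estimated step is a number 21 percentage points higher from compound 2 to compound 3 (beyond the scatter). For compound 3 the expected value is 80%, with an estimated range from 62% to 94%.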

Compound 3, percent of the compound remaining in the Homo sapiens assay: 17%
Estimate against measurement, compound 3: 63 percentage points above; measured number outside the range, below it.
By their numbers in the Homo sapiens assay, from the lowest: compound 3; then compound 2; then compound 1.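

In the Homo sapiens assay a sulfonyl group on this aromatic carbon does not by itself go with the high number of compound 1: the replacement of 2-hydroxyethyl by 3-hydroxypyrrolidin-1-yl on the sulfonyl sulfur gives a number 78 percentage points lower from compound 1 to compound 3 (beyond the scatter) and places compound 3 lowest of the three, while the change at the same aromatic carbon gives a number 42 percentage points lower from compound 2 to compound 3 (beyond the scatter), so the group carried by the sulfur separates compound 1 and compound 3 even though both keep the sulfonyl. For the compounds shown here, in a physicochemical assay for solubility, read by HPLC, using the shake flask method, measured as kinetic solubility, with a stated time of 20 h, at pH 6.5, tested at 200 uM (on this read-out lower numbers stand for lower solubility and higher numbers for higher solubility), the same change from the methanesulfonamido group gives no change at the digits printed from compound 2 to compound 3 (within the scatter), with compound 2 at 20000 nM and compound 3 at 20000 nM, so the large step on stability has no counterpart in this solubility read-out. Nothing available explains either large step.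

The compounds shown leave open which feature of the (3-hydroxypyrrolidin-1-yl)sulfonyl group goes with the low number: the nitrogen on the sulfur, the five-membered ring, the hydroxyl or the defined stereocentre. An open-chain 2-hydroxyethylamino group on the sulfonyl sulfur, an unsubstituted pyrrolidine and the opposite enantiomer of compound 3 would each separate these features.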